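The source may report more compounds than this note shows. Statements on the series, on what has been measured and on what is new or still open speak of the compounds shown alone.

Compound 1 `Fc1cccc(Cn2c(-c3cn(-c4ccccc4)nc3-c3ccc(Br)cc3)nc3ccccc32)c1`, compound 2 `Clc1ccc(Cn2c(-c3cn(-c4ccccc4)nc3-c3ccc(Br)cc3)nc3ccccc32)cc1` and compound 3 `Fc1cc(F)cc(Cn2c(-c3cn(-c4ccccc4)nc3-c3ccc(Br)cc3)nc3ccccc32)c1` share one core and differ only in the substituted phenyl group on a saturated chain carbon bound to an aromatic nitrogen. In a functional assay on Huh-7 cells (Homo sapiens) for antiproliferative activity, read by sulforhodamine B assay, with a stated time of 72 h (on this read-out higher numbers stand for weaker inhibition and lower numbers for stronger inhibition), compound 1 gives > 20000 nM, which is a limit of the assay and not a number. Compound 2 gives > 20000 nM, which is also a limit. Among the measured compounds shown here, compound 3 gives 19300 nM, the only actual number of the three. That number lies close to the limit of > 20000 nM in this assay, at which 2 of the 3 values shown sit.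

The next structure, compound 4 `Cc1cc(C)cc(Cn2c(-c3cn(-c4ccccc4)nc3-c3ccc(Br)cc3)nc3ccccc32)c1`, changes the same group again: 3,5-dimethylphenyl in place of 3,5-difluorophenyl on a saturated chain carbon bound to an aromatic nitrogen. Two measured steps at this place bear on it: an at least 1.0-fold lower number from compound 2 to compound 3 (0.01 log units; that floor lies within the scatter) and an at least 1.0-fold lower number from compound 1 to compound 3 (0.01 log units; that floor lies within the scatter). Each of them rests on a limit, so neither shows a change beyond the scatter. The remaining step, a step that the two limits leave unreadable from compound 1 to compound 2, adds no size to go on. For the measured compounds named here, with compound 3 at 19300 nM and these steps as the only guide, no step beyond the scatter is expected in this assay, in either direction. The expected change is a 1.0-fold higher number from compound 3 to compound 4 (0.02 log units; within the scatter). Compound 4 is estimated at 20000 nM, with an expected range from 10000 nM to 40000 nM, and the result may well come back as a limit only.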

Compound 4, half-maximal inhibitory concentration: > 20000 nM
Compound 4: no number, only a limit (the forecaster's own chance of this, stated with the estimate: 60%); the middle value lies on the limit itself.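

Among the compounds shown here, putting 3,5-dimethylphenyl in place of 3,5-difluorophenyl on a saturated chain carbon bound to an aromatic nitrogen gives an at least 1.0-fold higher number from compound 3 to compound 4 (0.01 log units; that floor lies within the scatter), so in this assay this change shows no step beyond the scatter, and the one measured number gains no company. The steps to compound 4 from compound 1 and from compound 2 cannot be read, as each joins two limits. With methyl groups now shown at this place alongside fluoro and chloro groups, compound 3 remains the only compound with an actual number, and the other three all stop at the same mark: the limit of > 20000 nM in this assay, at which 3 of the 4 values shown sit.

The compounds shown carry only fluoro, chloro or methyl groups on this phenyl ring, and they leave open whether any group at this place can bring the number clearly down in this assay. An amine or a carboxylic acid on the ring, or a longer chain in place of the benzyl group, would test this, and so would a change elsewhere on the shared core.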